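A few compounds are considered here, and "the series" means these few. Any claim that something is new, unique, unknown or untested is made for them only; others in the source may bear on it.

In a functional assay on the whole organism with Mus musculus as the target, in the maximal electroshock model (on this read-out higher numbers stand for an effect only at larger amounts of compound and lower numbers for an effect already at smaller amounts), compound 1 `C[C@@H](NCc1ccc(OCc2ccccc2)cc1)C(N)=O` gives 17.1 mg/kg, while compound 2 `CNC(=O)[C@H](C)NCc1ccc(OCc2ccccc2)cc1` gives 7 mg/kg, so compound 1 holds the higher of the two numbers. For the measured compounds named here, the only measured step, a 2.4-fold lower number from compound 1 to compound 2 (0.39 log units; beyond the scatter), swaps the group on the amine nitrogen. Compound 3 `C[C@@H](NCc1ccc(Oc2ccccc2)cc1)C(N)=O` keeps that group of compound 1 and differs at another place, with phenyl in place of benzyl on an oxygen on an aromatic ring. Going by the values given here, no measured step touches this place, so the step to compound 2 offers only a rough idea of how far a single change can move the number. A shift of similar modest size is expected in this assay, with an uncertain direction and a slight lean towards a higher number. The estimated change is a 1.3-fold higher number from compound 1 to compound 3 (0.11 log units; within the scatter). For compound 3 the expected value is 22 mg/kg, within an estimated range from 8 mg/kg to 60 mg/kg.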

Compound 3, dose for half-maximal effect: 41.5 mg/kg
The estimate for compound 3 lay 1.9-fold (0.28 log units) below the measured number; low and high end bracket the measured number.
By their numbers in this assay, from the lowest: compound 2; then compound 1; then compound 3.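

In this assay, phenyl in place of benzyl on an oxygen on an aromatic ring gives a 2.4-fold higher number from compound 1 to compound 3 (0.39 log units; beyond the scatter), so more of the compound is needed for the same effect. This shows that the group on this oxygen affects the result, and that the group on the amine nitrogen is not the only place that does. The change here runs in the opposite direction to the earlier step, a 2.4-fold lower number from compound 1 to compound 2 (0.39 log units; beyond the scatter), with the lower number coming from 1-(methylcarbamoyl)ethyl in place of 1-carbamoylethyl.

Going by these compounds, it remains open how the number would respond to a longer chain on this oxygen, such as phenylethyl, or to a fluorine atom on the benzyl ring. Nothing available here explains why the number rises with this change.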